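A few compounds are considered here, and "the series" means these few. Any claim that something is new, unique, unknown or untested is made for them only; others in the source may bear on it.

Values so far in a functional assay on CNE-2 cells (Homo sapiens) for cytotoxicity, read by sulforhodamine B assay, with a stated time of 48 h; a higher number here means a weaker inhibitor, a lower number a stronger inhibitor
- compound 1 `COc1ccc(/C=C/C(=O)c2ccc(NC(C)=O)c(-c3ccc(F)cc3)c2)cc1OC` gives 2740 nM
- compound 2 `COc1ccc(-c2cc(C(=O)/C=C/c3cc(OC)c(OC)c(OC)c3)ccc2N)cc1OC` gives 4330 nM
- compound 3 `COc1ccc(/C=C/C(=O)c2cccc(-c3cccc(F)c3)c2)cc1OC` gives 770 nM

Compound 1 (2740 nM) lies within the scatter of compound 2 (4330 nM), while compound 3 (770 nM) gives a lower number, beyond the scatter. Compound 4 `COc1ccc(/C=C/C(=O)c2ccc(N)c(-c3ccc(F)cc3)c2)cc1OC` differs from compound 1 by one change, hydrogen in place of acetyl on a nitrogen on an aromatic ring, which turns acetamido to amino. Within the data shown here, no measured pair isolates this change. Compound 2 also carries an amino group and gives 4330 nM in this assay with other differences in its structure, so no step beyond the scatter is expected. The step expected is a 1.4-fold lower number from compound 1 to compound 4 (0.14 log units; within the scatter) and it would stay small. Compound 4 is estimated at 2000 nM within an expected range from 700 nM to 5500 nM in this account.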

Compound 4, half-maximal inhibitory concentration: 3510 nM
The estimate for compound 4 lay 1.8-fold (0.24 log units) below the measured number, within the range that was stated.
By their numbers in this assay, from the lowest: compound 3; then compounds 1, 4 and 2 (each within the scatter of the next).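

Taking the acetyl off the nitrogen on the aromatic ring gives, in this assay, a 1.3-fold higher number from compound 1 to compound 4 (0.11 log units; within the scatter), the first step in this set that isolates a single change. At this position, acetamido and amino therefore cannot be told apart in this assay. Nothing shown accounts for this result.

The compounds shown leave open whether a methanesulfonyl or a butanoyl group on that nitrogen, or a dimethylamino group in its place, would give a step beyond the scatter. They also leave open whether the same change behaves alike on the core of compound 2.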